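Estimating Cytotoxicity After Swapping One Aromatic Tail

The source may report more compounds than this note shows. Statements on the series, on what has been measured and on what is new or still open speak of the compounds shown alone.

Compound 1 `CC(C)(NC(=O)c1ccc([N+](=O)[O-])o1)c1ccc(Cl)cc1`: 81000 nM
Compound 2 `CC(C)(NC(=O)c1ccc([N+](=O)[O-])o1)c1ccc(Oc2ccc(Cl)cc2)cc1`: 67000 nM

Both compounds were tested in an ADME assay on Vero cells (Chlorocebus sabaeus) for cytotoxicity, read by MTT assay, with a stated time of 48 h; on this read-out lower numbers stand for higher toxicity in this test and higher numbers for lower toxicity in this test. Compound 1 gives 81000 nM and compound 2 gives 67000 nM in this assay. Among the compounds with values here, the step of a 1.2-fold lower number from compound 1 to compound 2 (0.08 log units; within the scatter) is the only measured step, and it places compound 2 within the scatter of compound 1, so neither compound can be called more or less toxic than the other.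

Compound 3 `COc1ccc(OCc2ccc(C(C)(C)NC(=O)c3ccc([N+](=O)[O-])o3)cc2)cc1` differs from compound 2 in one place: (4-methoxyphenoxy)methyl in place of 4-chlorophenoxy on an aromatic carbon. Within the data shown here, the one measured step that touches this same position, a 1.2-fold lower number from compound 1 to compound 2 (0.08 log units; within the scatter), was small. Nothing in the data points to a larger effect from the new group, so compound 3 is expected to stay close to compound 2 in this assay. The expected step is a 1.1-fold lower number from compound 2 to compound 3 (0.05 log units; within the scatter). For compound 3 the estimated value is 60000 nM, with a range from 25000 nM to 150000 nM.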

Compound 3, half-maximal cytotoxic concentration: > 120000 nM
Compound 3: only a limit was reported (the forecaster's own chance of this, stated with the estimate: 20%); middle value at least 2.0-fold (0.30 log units) from the limit.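

In this assay, the reading for compound 3 is a limit and not a number: the limit of > 120000 nM in this assay, at which 1 of the 3 values shown sits. The two steps to it can therefore be read only as floors: an at least 1.7-fold higher number from compound 2 to compound 3 (0.25 log units; that floor lies within the scatter), and an at least 1.4-fold higher number from compound 1 to compound 3 (0.17 log units; that floor lies within the scatter). This position on the aromatic ring thus carries a second, different aryl ether tail, (4-methoxyphenoxy)methyl, with no drop in the number, but neither floor clears the scatter, and compound 3 cannot yet be called less toxic than compound 2 or compound 1.

The compounds shown do not separate the two parts of the swap, the methoxy group in place of chloro and the added carbon link to the oxygen. They also leave open how an amine or a carboxylic acid at this position would read in this assay.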